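Swapping Trifluoromethyl for Methyl on the Amide

The compounds below may be only part of what the source reports. "The series", "measured", "known", "first", "only" and "open" are said of these compounds alone.

Measured so far:
compound 1, `Cc1nc(S(=O)(=O)Nc2ccc(Cc3nc4c([nH]3)c(=O)n(Cc3ccccc3F)c(=O)n4CC3CC3)cc2)cn1C`, gives 340 nM in an assay on isolated protein for inhibition of phosphoenolpyruvate carboxykinase, cytosolic [GTP] (Homo sapiens); a lower number here means a stronger inhibitor, a higher number a weaker inhibitor.
compound 2, `CCCCn1c(=O)n(Cc2ccccc2F)c(=O)c2[nH]c(Cc3ccc(NC(=O)C(F)(F)F)cc3)nc21`, gives 2300 nM in this assay.

Compound 2 has the highest number of the two, so it is the weaker inhibitor, and its gap to compound 1 lies beyond the usual scatter. Compound 3, `CCCCn1c(=O)n(Cc2ccccc2F)c(=O)c2[nH]c(Cc3ccc(NC(C)=O)cc3)nc21`, is not yet measured. It differs from compound 2 in one place only: methyl in place of trifluoromethyl on a carbonyl carbon. Among the compounds with values here, with no measured pair showing this same change, the step from compound 2 to compound 3 is expected to be small, within the scatter, as a 1.3-fold higher number from compound 2 to compound 3 (0.12 log units; within the scatter). For compound 3 the expected value is 3000 nM, within a range from 1000 nM to 9000 nM.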

Compound 3, half-maximal inhibitory concentration: 2110 nM
The estimate for compound 3 lay 1.4-fold (0.15 log units) above the measured number; the range from low to high includes it.
By their numbers in this assay, from the lowest: compound 1; then compounds 3 and 2 (each within the scatter of the next).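

Within this assay the swap of trifluoromethyl for methyl on this carbonyl carbon gives a 1.1-fold lower number from compound 2 to compound 3 (0.04 log units; within the scatter) and so leaves the two compounds indistinguishable. Within the data shown here, this pair is the first to isolate the change, and it shows that, with the rest of the molecule held fixed, this assay does not separate the acetamido form from the ((trifluoromethyl)carbonyl)amino form. No measurement at hand offers an explanation for this. Still open, from the compounds shown here alone, is whether a larger group on this carbonyl carbon, such as a phenyl ring or a longer chain, would separate from these two. An amine in place of the methyl remains equally untested here.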